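The compounds below may be only part of what the source reports. "The series", "measured", "known", "first", "only" and "open" are said of these compounds alone.

For the measured compounds named here, in an ADME assay on liver for metabolic stability, with Liver microsome (Rattus norvegicus) as the target, read by LC-MS, using microsomes, with a stated time of 5 h (a lower number here means slower removal, a higher number faster removal of the compound), three compounds have a measured number so far. Compound 1 (`OC(c1ccccn1)C1(c2ccc(Cl)c(Cl)c2)COC1`) gives 417 mL/min/kg as its clearance, and compound 2 (`CN1CC(c2ccc(C(F)(F)F)cc2)(C(O)c2ccccn2)C1`) gives 117 mL/min/kg as its clearance. Compound 3 (`C[C@]1(O)C[C@](c2ccnc(C(F)(F)F)c2)([C@H](O)c2ccccn2)C1`) gives 83.3 mL/min/kg as its clearance. That places compound 3 beyond the scatter from compound 1, on the side of slower removal, while compound 2 and compound 3 cannot be told apart, since their gap lies within the scatter.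

Compound 4 (`C[C@]1(O)C[C@@](c2ccnc(C(F)(F)F)c2)([C@H](O)c2ccccn2)C1`) has no number yet. It is very close to compound 3 (the two compounds have the same atoms and bonds and differ only in configuration as drawn: 2 of 3 stereo elements differ; a stereocentre at a saturated ring carbon is drawn S in compound 3 and R in compound 4; a stereocentre at a saturated ring carbon is drawn r in compound 3 and s in compound 4). Nothing leaves and nothing enters: the two compounds have the same atoms and bonds and differ only in configuration as drawn, at stereocentres on saturated ring carbons.

Going by the values given here, no two measured compounds differ in one place only, so the data do not show how far a change of configuration alone moves clearance, or in which direction. The expectation is therefore no shift beyond the scatter. The estimated step (a 1.1-fold higher number from compound 3 to compound 4 (0.03 log units; within the scatter)) is small and has no firm direction. For compound 4 the expected value in this assay is 90 mL/min/kg (estimated range 40 mL/min/kg to 200 mL/min/kg).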

Compound 4, clearance: 50 mL/min/kg
The estimate for compound 4 lay 1.8-fold (0.26 log units) above the measured number, and the stated range covers the measured number.
By their numbers in this assay, from the lowest: compounds 4, 3 and 2 (each within the scatter of the next, the first and the last beyond it); then compound 1.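

In this assay, changing the configuration as drawn at the saturated ring carbons gives a 1.7-fold lower number from compound 3 to compound 4 (0.22 log units; within the scatter). For the compounds shown here, this is the first step that isolates a single kind of change, and it shows that, for this pair, redrawing these stereocentres does not move clearance beyond the usual scatter of repeated measurements. Any gap between the two numbers cannot be assigned to a gain or loss of atoms, and the comparison is a clean one: the fact that compounds 3 and 4 differ only in the configuration as drawn.

On these data alone, the two stereocentres differ together in this pair, so the separate contribution of each one remains unknown, and a real but small effect of configuration cannot be ruled out from a single pair. As far as these compounds go, it also remains open whether a change of configuration would stay this small if the shared core carried an amine or a carboxylic acid instead of its present groups.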